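A few compounds are considered here, and "the series" means these few. Any claim that something is new, unique, unknown or untested is made for them only; others in the source may bear on it.

Of the compounds shown here, two sharing one core have been measured in a functional assay on NCI-H460 cells (Homo sapiens); a higher number here means a weaker inhibitor of growth, a lower number a stronger inhibitor of growth. There, compound 1 `COc1cccc(-c2cc(O)c3cc(C)cnc3n2)c1` gives 43.7 nM and compound 2 `COc1cccc(-c2cc(O)c3c(C)ccnc3n2)c1` gives 47.9 nM. Compound 2 therefore stands level with compound 1, since the two values lie within the usual scatter of each other.

The next compound, compound 3 `COc1cccc(-c2cc(O)c3cccnc3n2)c1`, is related to compound 2 by a single change, hydrogen in place of methyl on an aromatic carbon, opposite the ring nitrogen. Among the measured compounds shown here, both measured compounds carry a methyl on the core, and no measured pair shows what losing it does in this assay. The size of this step therefore cannot be read from the data, and any expectation remains tentative. A modest move towards weaker growth inhibition seems more likely than none, though a result within the scatter of compound 2 at 47.9 nM would not be surprising. The expected change is a 1.7-fold higher number from compound 2 to compound 3 (0.22 log units; within the scatter). For compound 3 the estimated value is 80 nM, with an expected range from 30 nM to 250 nM.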

Compound 3, concentration for 50% growth inhibition: 91.2 nM
Estimate against measurement, compound 3: 1.1-fold (0.06 log units) below, and the stated range covers the measured number.
By their numbers in this assay, from the lowest: compounds 1, 2 and 3 (each within the scatter of the next, the first and the last beyond it).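

With this result, this assay gives its first reading of what losing the methyl does. At the aromatic carbon opposite the ring nitrogen, hydrogen in place of methyl gives a 1.9-fold higher number from compound 2 to compound 3 (0.28 log units; within the scatter), so this step alone does not show that the methyl at this position matters for growth inhibition. The same kind of change starting from compound 1, whose methyl stands on a different aromatic carbon of the shared core, gives a 2.1-fold higher number from compound 1 to compound 3 (0.32 log units; beyond the scatter), a modest step and the only one of the two that lies beyond the scatter, while nothing available here explains either step.

The compounds leave open what a group other than hydrogen or methyl would do on the carbon opposite the ring nitrogen, for example a longer chain such as ethyl, a halogen such as chlorine, a methoxy or an amine. They also leave open whether methyl groups on both of these carbons together would give a number different from those of compound 1 and compound 2.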